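Working notes on cytotoxicity in a small boron-bearing series

The source may hold more compounds than are shown below. What is called first, only, known or untested is meant among the compounds shown, and "the series" means these compounds.

Measured so far:
- compound 1 `O=C(/C=C/c1ccc2c(c1)B(O)OC2)c1ccccc1`: > 10 ug/mL, a limit of the assay
- compound 2 `COCOc1ccccc1C(=O)/C=C/c1ccc2c(c1)B(O)OC2`: 9.02 ug/mL
- compound 3 `COCOc1cccc(C(=O)/C=C/c2ccc3c(c2)B(O)OC3)c1`: > 10 ug/mL, a limit of the assay

In an ADME assay on L929 cells (Mus musculus) for cytotoxicity, read by resazurin assay, with a stated time of 72 h (on this read-out higher numbers stand for weaker inhibition and lower numbers for stronger inhibition), compound 1 gives > 10 ug/mL, which is a limit and not a number. Compound 2 gives 9.02 ug/mL in this assay. Compound 3 gives > 10 ug/mL, again a limit. The step of an at least 1.1-fold lower number from compound 1 to compound 2 (0.04 log units; that floor lies within the scatter) stays within the scatter, and the step that the two limits leave unreadable from compound 1 to compound 3 cannot be sized. Two of the three values sit at the limit of > 10 ug/mL in this assay, at which 2 of the 3 values shown sit, so compound 1 is pinned only from one side.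

Compound 4 `O=C(/C=C/c1ccc2c(c1)B(O)OC2)c1ccc(F)cc1` differs from compound 1 by a single change: fluoro in place of hydrogen on an aromatic carbon. Going by the values given here, no measured step concerns fluoro in place of hydrogen; the two steps on record concern methoxymethoxy, and neither reads beyond the scatter. In this assay, therefore, no step beyond the scatter is expected from compound 1 to compound 4. Compound 4 is expected to give about 12 ug/mL, with a range from 6 ug/mL to 30 ug/mL. The expected step is a step that the limit leaves unreadable from compound 1 to compound 4, most likely again reported only as a limit.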

Compound 4, half-maximal inhibitory concentration: > 10 ug/mL
Compound 4: only a limit was reported; the forecaster's own chance of this, stated with the estimate: 70%; the middle value does not contradict the limit.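

No new step can be read in this assay between compound 1 and compound 4: each stands only as a limit of the assay. The compounds shown leave open whether fluoro in place of hydrogen shifts the value at all, with most of the series sitting at one edge: the limit of > 10 ug/mL in this assay, at which 3 of the 4 values shown sit.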